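Chalcone series: methylsulfanyl to fluorophenyl swap, PC-3 proliferation

This account rests on a few compounds, and the source may have more. Where it says the series, first, only, none or still open, it means among the compounds named here.

Among the measured compounds shown here, compound 2 `COc1cc(OC)c(C(=O)/C=C/c2ccccc2SC)c(OC)c1` gives 0% in a functional assay on PC-3 cells (Homo sapiens), read by fluorescence and BrdU incorporation, with a stated time of 48 h, tested at 25 uM (a higher number here means a weaker effect of the compound at the concentration tested, a lower number a stronger effect), the smallest of the three numbers so far; compound 3 `COc1cc(OC)c(C(=O)/C=C/c2ccccc2)c(OC)c1` sits within the scatter of it at 1.7%, while compound 1 `COc1cc(O)c(C(=O)/C=C/c2ccc(F)cc2)c(OC)c1` gives 34%, a gap from compound 2 that lies beyond the scatter. Compound 4 `COc1cc(OC)c(C(=O)/C=C/c2ccc(F)cc2)c(OC)c1` has not been measured. Against compound 2 the change is 4-fluorophenyl in place of 2-(methylsulfanyl)phenyl on a double-bonded chain carbon bound to a double-bonded chain carbon. For the measured compounds named here, the one measured step bearing on this is a number 1.7 percentage points higher from compound 2 to compound 3 (within the scatter), a shift within the scatter. Going by the values given here, compound 1 carries the same 4-fluorophenyl on a core with a hydroxyl where compound 4 carries a methoxy, and its number is the only high one here; no step between those two is computed. For compound 4 the expected step is a number 6 percentage points higher from compound 2 to compound 4 (within the scatter). Compound 4 is estimated at 6%, within 0% to 22%.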

Compound 4, a percentage reported as activity, at one concentration (the size of the read-out at that concentration, not a potency): 0.4%
The estimate for compound 4 lay 5.6 percentage points above the measured number; the range from low to high includes it.
By their numbers in this assay, from the lowest: compounds 2, 4 and 3 (each within the scatter of the next); then compound 1.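

In this assay, 4-fluorophenyl in place of 2-(methylsulfanyl)phenyl on this chain carbon stays within the scatter (a number 0.4 percentage points higher from compound 2 to compound 4 (within the scatter)), as does fluoro in place of hydrogen on an aromatic carbon (a number 1.3 percentage points lower from compound 3 to compound 4 (within the scatter)). The large step lies on the core instead: methyl in place of hydrogen on an oxygen on an aromatic ring gives a number 33.6 percentage points lower from compound 1 to compound 4 (beyond the scatter), so the high number of compound 1 goes with its hydroxyl, not its 4-fluorophenyl. No measurement shown explains this.

As far as these compounds go, what an amine or a carboxylic acid in place of the fluoro would give remains open. So does the effect of a longer chain than methyl on that core oxygen.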